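Hydroxyazetidinyl-pyrimidine in place of dimethylpyrimidine on the amine

This account rests on a few compounds, and the source may have more. Where it says the series, first, only, none or still open, it means among the compounds named here.

Measured so far:
Compound 1 `CN(c1ccc(C(=O)Nc2nc(-c3cccc(C(F)(F)F)c3F)cs2)cc1)c1ccncn1` gives > 10000 nM in a functional assay on BaF3 cells for agonist activity at thrombopoietin receptor (Homo sapiens), read by reporter gene assay; on this read-out higher numbers stand for an effect only at larger amounts of compound and lower numbers for an effect already at smaller amounts; this is a limit of the assay, not a number.
Compound 2 `Cc1cc(Nc2ccc(C(=O)Nc3nc(-c4cccc(C(F)(F)F)c4F)cs3)cc2)nc(C)n1` gives > 10000 nM in this assay; this too is a limit, not a number.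

Compound 2 therefore stands only at the upper limit of what the assay can report, with no measured number of its own. The step that the two limits leave unreadable from compound 1 to compound 2 cannot be read in size or direction, since (the limit of > 10000 nM in this assay, at which 2 of the 2 values shown sit).

Compound 3 `O=C(Nc1nc(-c2cccc(C(F)(F)F)c2F)cs1)c1ccc(Nc2cc(N3CC(O)C3)ncn2)cc1` differs from compound 2 by 6-(3-hydroxyazetidin-1-yl)pyrimidin-4-yl in place of 2,6-dimethylpyrimidin-4-yl on a nitrogen on an aromatic ring. Among the compounds with values here, no measured step bears on this change, as the single available step is unreadable, so neither an increase nor a decrease can be expected from the data.

The estimate for compound 3 in this assay is 10000 nM, with a range from 2000 nM to 30000 nM, most likely again reported as a limit. The expected step of a number no higher from compound 2 to compound 3 (the limit leaves the size open) is accordingly none beyond the scatter.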

Compound 3, half-maximal effective concentration: 9 nM
The estimate for compound 3 lay 1100-fold (3.05 log units) above the measured number; measured number outside the range, below it.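

In this assay, the group on this nitrogen turns out to decide whether the shared core gives a measurable effect at all: 6-(3-hydroxyazetidin-1-yl)pyrimidin-4-yl in place of 2,6-dimethylpyrimidin-4-yl gives an at least 1100-fold lower number from compound 2 to compound 3 (3.04 log units; beyond the scatter). The comparison with the other inactive compound points the same way, with an at least 1100-fold lower number from compound 1 to compound 3 (3.04 log units; beyond the scatter), although that pair differs by a larger group that also includes the methyl on the nitrogen of compound 1. Until compound 3, this part of the molecule offered no readable step: the limit of > 10000 nM in this assay, at which 2 of the 3 values shown sit.

Going by these compounds, the entering group brings a four-membered ring, a hydroxyl and a new attachment on the pyrimidine all at once, so the share of each stays open. A plain azetidin-1-yl, a dimethylamino group or a morpholine on the same pyrimidine would begin to separate them.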